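Cyclic urea in place of cyanoguanidine: stability outlook

The source may report more compounds than this note shows. Statements on the series, on what has been measured and on what is new or still open speak of the compounds shown alone.

In an ADME assay on microsomes from liver (Rattus norvegicus) for metabolic stability (a lower number here means that the compound disappears faster, a higher number that the compound lasts longer), compound 1 `CCn1ncc2c(F)cc(-c3ccc(C(CC)(CC)c4nnc(C)[nH]4)c(=O)[nH]3)cc21` gives > 3 h, which is a limit of the assay and not a number, as noted in the limit of > 3 h in this assay, at which 1 of the 3 values shown sits. Among the numbers, compound 3 `CC(C)C(c1ccc(-c2ccc3cccc(F)c3c2)[nH]c1=O)N1CCN/C1=N\C#N` gives 0.327 h, and compound 2 `CC(C)[C@H](C[C@H]1CCNC1=O)c1ccc(-c2ccc3cccc(F)c3c2)[nH]c1=O` gives 0.227 h; these two sit within the scatter of each other, so no order between them is read. Compound 4 `CC(C)C(c1ccc(-c2ccc3cccc(F)c3c2)[nH]c1=O)N1CCNC1=O` is not yet measured in this assay. It differs from compound 3 by a group of 6 heavy atoms (3 carbon, 2 nitrogen, 1 oxygen; one five-membered non-aromatic ring with 2 hetero atoms) in place of a group of 8 heavy atoms (4 carbon, 4 nitrogen; one five-membered non-aromatic ring with 2 hetero atoms), on a saturated chain carbon bound to an aromatic carbon and a saturated chain carbon. Among the measured compounds shown here, no measured pair follows this change, so the expected step from a 1.1-fold lower number from compound 3 to compound 4 (0.04 log units; within the scatter) is none beyond the scatter. The estimate for compound 4 in this assay is 0.3 h, with a range from 0.12 h to 0.8 h.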

Compound 4, half-life: 0.283 h
The estimate for compound 4 lay 1.1-fold (0.03 log units) above the measured number; low and high end bracket the measured number.
By their numbers in this assay, from the lowest: compounds 2, 4 and 3 (each within the scatter of the next). At a limit, above all of these: compound 1.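

In this assay, the change at the saturated chain carbon bound to an aromatic carbon and a saturated chain carbon gives a 1.2-fold lower number from compound 3 to compound 4 (0.06 log units; within the scatter). This first measured pair at this place shows that 2-oxoimidazolidin-1-yl and the nitrile-bearing ring it replaces cannot be told apart in this read-out. Nothing measured here bears on a reason for this result. The compounds shown leave open how an amine or a carboxylic acid on this carbon would read in this assay. They also leave open whether any group at this place moves the half-life beyond the scatter.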